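The source may report more compounds than this note shows. Statements on the series, on what has been measured and on what is new or still open speak of the compounds shown alone.

Compound 1 `COc1ccc(CN(c2cc(OC)c(OC)c(OC)c2)S(=O)(=O)c2ccc(C)cc2)cc1`: 10100 nM
Compound 2 `COc1ccc(CN(c2cc(OC)c(OC)c(OC)c2)S(=O)(=O)c2ccccc2)cc1`: > 50000 nM
Compound 3 `Cc1ccc(S(=O)(=O)N(Cc2nc3ccccc3[nH]2)c2ccccc2)cc1`: 49700 nM

All three were tested in a functional assay on MCF7 cells (Homo sapiens) for inhibition, read by MTT assay, with a stated time of 48 h; on this read-out lower numbers stand for stronger inhibition and higher numbers for weaker inhibition. Compound 2 reaches only a limit of the assay, > 50000 nM. Compound 1 differs from compound 2 in one place, (methyl in place of hydrogen on an aromatic carbon), and the step of an at least 4.9-fold lower number from compound 2 to compound 1 (0.69 log units; beyond the scatter) follows from it; its exact size is open because of the limit of > 50000 nM in this assay, at which 1 of the 3 values shown sits. How the core of compound 3 differs from that of compound 2 is not broken down here. Compound 4 `Cc1ccc(N(Cc2nc3ccccc3[nH]2)S(=O)(=O)c2ccc(C)cc2)cc1` has not been measured; it differs from compound 3 by methyl in place of hydrogen on an aromatic carbon. Within the data shown here, this is the same kind of change as the one from compound 2 to compound 1, not the same: there, cut one bond further out, the difference also reads phenylsulfonyl to (4-methylphenyl)sulfonyl, which it does not here. For compound 4 a smaller gain is expected, a 2.5-fold lower number from compound 3 to compound 4 (0.40 log units; beyond the scatter), since the only measured case is an at least 4.9-fold lower number from compound 2 to compound 1 (0.69 log units; beyond the scatter). Compound 4 is therefore estimated at about 20000 nM, most likely between 6000 nM and 60000 nM.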

Compound 4, half-maximal inhibitory concentration: > 50000 nM
Compound 4 ended at the assay's limit; the forecaster's own chance of this, stated with the estimate: 25%; middle value at least 2.5-fold (0.39 log units) from the limit.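

In this assay the new step reads a number no lower from compound 3 to compound 4 (the limit leaves the size open). Methyl in place of hydrogen therefore does not bring the same gain on both cores, so the gain seen on the core of compound 2 cannot simply be carried over to the core of compound 3: the same change on two cores in this assay, an at least 4.9-fold lower number (0.69 log units; beyond the scatter) from compound 2 to compound 1 and a number no lower (the limit leaves the size open) from compound 3 to compound 4, at least 4.9-fold (0.69 log units) apart, beyond the scatter of two such steps Neither step has an exact size, and the comparison shows only that these two steps differ, not how far apart they really are, because values sit at the assay's limit: the limit of > 50000 nM in this assay, at which 2 of the 4 values shown sit.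

The two pairs also differ in where the methyl goes, since it gives (4-methylphenyl)sulfonyl in compound 1 but 4-methylphenyl in compound 4, so the compounds shown cannot separate the effect of the core from that of the ring carrying the methyl. Also open, as far as these compounds go, is whether a different group in that place, such as an amine or a carboxylic acid, would lower the number on either core.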